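The compounds below may be only part of what the source reports. "The series", "measured", "known", "first", "only" and "open" are said of these compounds alone.

Measured compounds, with their read-out in a functional assay on the whole organism with Rattus norvegicus as the target, at a dose of 20 mg/kg by the oral route; on this read-out lower numbers stand for less inhibition and higher numbers for more inhibition at the one dose given (going by the name of the read-out):
Compound 1 `NC(=O)/C=C1\CCc2c(Cl)cccc21` gives 58%.
Compound 2 `NC(=O)/C=C1\CCc2ccc(Br)cc21` gives 21%.
Compound 3 `O=C(/C=C1\CCc2ccc(Br)cc21)NC1CC1` gives 4%.

Compound 1 stands highest of the three measured values; its nearest neighbour is compound 2, and that gap is beyond the scatter, as is the larger gap to compound 3. The difference between the core of compound 1 and the core of compound 2 is not broken down here. On the core of compound 2, the change cyclopropyl in place of hydrogen on an amide-type nitrogen brought a step of a number 17 percentage points lower from compound 2 to compound 3 (beyond the scatter) in this assay, a modest fall beyond the scatter.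

Compound 4 `O=C(/C=C1\CCc2c(Cl)cccc21)NC1CC1` is not yet measured. It carries the same change, (cyclopropyl in place of hydrogen on an amide-type nitrogen), made on the core of compound 1; the place of the change reads the same in both cases, so this is the same change, not merely the same kind. Among the compounds with values here, only one example of it is measured, on a different core, so the expectation rests on a single step. The expected step from compound 1 to compound 4 in this assay is a number 17 percentage points lower from compound 1 to compound 4 (beyond the scatter), resting on a number 17 percentage points lower from compound 2 to compound 3 (beyond the scatter). Compound 4 is therefore estimated at 41%, expected to fall between 26% and 56%.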

Compound 4, a percentage reported as inhibition, in the whole organism at one dose (the size of the read-out at that dose, not a potency): 45%
Beside the measured number, compound 4's estimate is 4 percentage points below it; the measured number falls inside the stated range.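

In this assay, cyclopropyl in place of hydrogen on an amide-type nitrogen brings a number 13 percentage points lower from compound 1 to compound 4 (beyond the scatter), and the change carries from one core to the other with a step of matching size: the same change on two cores in this assay, a number 17 percentage points lower (beyond the scatter) from compound 2 to compound 3 and a number 13 percentage points lower (beyond the scatter) from compound 1 to compound 4, 4 percentage points apart, within the scatter of two such steps. The two steps run in the same direction from clearly different starting levels, with compound 2 at 21% and compound 1 at 58%, so on these two cores the change reads as a fall of similar size in percentage points. This rests on two pairs at a single oral dose, so it does not establish that the step holds on other cores or over other doses, and it gives no reason for the fall.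

The compounds shown leave open whether methyl or a longer chain on the amide-type nitrogen would give a similar fall. They also leave open which part of the difference between the core of compound 1 and the core of compound 2 goes with the higher level of compound 1.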